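Removing a Methoxy from the Shared Core of Compound 2

The source may report more compounds than this note shows. Statements on the series, on what has been measured and on what is new or still open speak of the compounds shown alone.

Of the compounds shown here, two have been measured so far, and they share one core. Compound 1 `COc1ccc2[nH]cc(C(=O)/C(C#N)=C/C=C(\Cl)c3ccc(OC)c(OC)c3)c2c1` gives 34.2% in a functional assay for inhibition, with a stated time of 30 min, tested at 1 mM; a lower number here means less inhibition, a higher number more inhibition at the concentration tested (going by the name of the read-out). Compound 2 `COc1ccc2[nH]cc(C(=O)/C(C#N)=C/C=C(\Cl)c3ccc(Br)cc3)c2c1` gives 40.8% in this assay. Going by the values given here, the single step recorded between them is a number 6.6 percentage points higher from compound 1 to compound 2 (within the scatter). The two compounds differ on the chain: 4-bromophenyl in place of 3,4-dimethoxyphenyl on a double-bonded chain carbon bound to a chlorine atom and a double-bonded chain carbon. On the numbers shown compound 2 stands first of the two, but the gap to compound 1 is within the scatter, so the two are not told apart.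

Compound 3 `N#C/C(=C\C=C(/Cl)c1ccc(Br)cc1)C(=O)c1c[nH]c2ccccc12` remains to be measured. Its difference from compound 2 is hydrogen in place of methoxy on an aromatic carbon. Among the compounds with values here, this change sits on the shared core rather than on the chain, and no measured step touches that part of the molecule. Within the data shown here, the only step available, between compound 1 and compound 2, concerns a different place and stayed within the scatter, so it gives no direct guide. With nothing pointing either way, the expected step for compound 3 is a number 0.8 percentage points lower from compound 2 to compound 3 (within the scatter) in this assay, meaning no change beyond the scatter. Compound 3 is therefore estimated at 40%, within a range from 25% to 55%.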

Compound 3, a percentage reported as inhibition, at one concentration (the size of the read-out at that concentration, not a potency): 18.4%
Estimate against measurement, compound 3: 21.6 percentage points above; measured number outside the range, below it.
By their numbers in this assay, from the lowest: compound 3; then compounds 1 and 2 (each within the scatter of the next).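

In this assay the methoxy on the shared core turns out to count, with a step (a number 22.4 percentage points lower from compound 2 to compound 3 (beyond the scatter)) that is the first among these compounds to lie beyond the scatter. The earlier step, made on the chain, could not tell its two compounds apart, whereas this one shows that, with the 4-bromophenyl group in place, the reading depends on what sits on this aromatic carbon: methoxy gives the higher number and hydrogen the lower. Nothing measured here explains why taking away the methoxy lowers the number, and the step stands as an observation without a known cause.

The compounds shown carry only methoxy or hydrogen at this position, and it remains open whether another group there, such as a hydroxyl, a chlorine atom or a longer ethoxy chain, would give a number closer to that of compound 2 or that of compound 3. It is also open whether the same loss would appear with the 3,4-dimethoxyphenyl group of compound 1 on the chain, as the one pair shown carries the 4-bromophenyl group only.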